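Rearranging the Ring of Compound 3

A few compounds are considered here, and "the series" means these few. Any claim that something is new, unique, unknown or untested is made for them only; others in the source may bear on it.

In a functional assay on V79-379A cells (Cricetulus griseus) for cytotoxicity, read by MTT assay, in the presence of a further agent that is not named here (a lower number here means a stronger inhibitor, a higher number a weaker inhibitor), compound 1 `COC1=CC(=O)c2c(c(COc3ccccc3)c(C)n2C)C1=O` gives 12000 nM, compound 2 `COC1=CC(=O)c2c(c(COc3ccc(F)cc3)c(C)n2C)C1=O` gives 31000 nM and compound 3 `COC1=CC(=O)c2c(c(Cc3cc(F)ccc3O)c(C)n2C)C1=O` gives 200000 nM, the highest of the three numbers. Compound 4 `COC1=CC(=O)c2c(c(Cc3ccc(O)c(F)c3)c(C)n2C)C1=O` has the same atoms as compound 3, joined differently: 3-fluoro-4-hydroxyphenyl in place of 5-fluoro-2-hydroxyphenyl on a saturated chain carbon bound to an aromatic carbon. The closest evidence comes from replacing phenoxy groups with the 5-fluoro-2-hydroxyphenyl group: a large step of a 17-fold higher number from compound 1 to compound 3 (1.22 log units; beyond the scatter) and a modest one a 6.5-fold higher number from compound 2 to compound 3 (0.81 log units; beyond the scatter). Adding fluoro gave a modest step of a 2.6-fold higher number from compound 1 to compound 2 (0.41 log units; beyond the scatter). Among the measured compounds shown here, no measured pair tests this rearrangement alone, so a modest move to a lower number is only a cautious expectation. The expected step is a 2.5-fold lower number from compound 3 to compound 4 (0.40 log units; beyond the scatter). For compound 4 the estimate is 80000 nM, with an expected range from 25000 nM to 250000 nM.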

Compound 4, half-maximal inhibitory concentration: 470000 nM
The estimate for compound 4 lay 5.9-fold (0.77 log units) below the measured number, outside the stated range (above it).
By their numbers in this assay, from the lowest: compound 1; then compound 2; then compound 3; then compound 4.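

Exchanging 5-fluoro-2-hydroxyphenyl for 3-fluoro-4-hydroxyphenyl gives a 2.4-fold higher number from compound 3 to compound 4 (0.37 log units; beyond the scatter) in this assay and so yields a weaker inhibitor, showing that the arrangement of the same atoms on this ring alone can shift the number. Compared with the phenoxy compounds, the gap grows to a 15-fold higher number from compound 2 to compound 4 (1.18 log units; beyond the scatter) and to a 39-fold higher number from compound 1 to compound 4 (1.59 log units; beyond the scatter) and leaves compound 4 the weakest of the four. Nothing available here explains this step. Going by these compounds, whether an amine or a carboxylic acid in place of the hydroxy group, or a longer chain at this position, would give a lower number remains open.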